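A few compounds are considered here, and "the series" means these few. Any claim that something is new, unique, unknown or untested is made for them only; others in the source may bear on it.

Measured in an assay on microsomes from liver for inhibition of 3-hydroxy-3-methylglutaryl-coenzyme A reductase (Rattus norvegicus); a lower number here means a stronger inhibitor, a higher number a weaker inhibitor:
compound 1 `CC(C)c1c(C(=O)NCC2CCCCC2)nn(-c2ccc(F)cc2)c1OC[C@@H](O)C[C@@H](O)CC(=O)O` gives 17 nM
compound 2 `CC(C)c1c(C(=O)NCc2cccc(F)c2F)nn(-c2ccc(F)cc2)c1OC[C@@H](O)C[C@@H](O)CC(=O)O` gives 2 nM
compound 3 `CC(C)c1c(C(=O)NCc2cccc(Cl)c2)nn(-c2ccc(F)cc2)c1OC[C@@H](O)C[C@@H](O)CC(=O)O` gives 5.4 nM

Compound 3 stands second highest of the three numbers in this assay; its nearest neighbour is seen in a 2.7-fold higher number from compound 2 to compound 3 (0.43 log units; beyond the scatter), its furthest in a 3.1-fold lower number from compound 1 to compound 3 (0.50 log units; beyond the scatter).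

Compound 4 `CC(C)c1c(C(=O)N(C)Cc2ccc(F)cc2)nn(-c2ccc(F)cc2)c1OC[C@@H](O)C[C@@H](O)CC(=O)O` has not yet been measured in this assay. Its difference from compound 3: (4-fluorobenzyl)(methyl)amino in place of (3-chlorobenzyl)amino on a carbonyl carbon. The measured steps that touch this place are an 8.5-fold lower number from compound 1 to compound 2 (0.93 log units; beyond the scatter), a 3.1-fold lower number from compound 1 to compound 3 (0.50 log units; beyond the scatter) and a 2.7-fold higher number from compound 2 to compound 3 (0.43 log units; beyond the scatter); each exchanges the group on the saturated chain carbon bound to the amide-type nitrogen, and each moved the number by a modest amount. None of them removes the hydrogen-bond donor that the change to compound 4 takes away, and none adds a methyl on the nitrogen, so that part of the change is uncovered by the data. The exchange of one halogenated aromatic ring for another alone would be expected to stay within the span of compounds 1 to 3. For compound 4 a modest rise in the number is expected, a 3.7-fold higher number from compound 3 to compound 4 (0.57 log units; beyond the scatter), with a wide range. Compound 4 is estimated at 20 nM, between 5 nM and 80 nM.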

Compound 4, half-maximal inhibitory concentration: 18 nM
Estimate against measurement, compound 4: 1.1-fold (0.05 log units) above, and the stated range covers the measured number.
By their numbers in this assay, from the lowest: compound 2; then compound 3; then compounds 1 and 4 (each within the scatter of the next).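

Compound 4 is the only compound shown without the amide hydrogen, and in this assay the group on the carbonyl carbon still gives a modest change with this loss: a 3.3-fold higher number from compound 3 to compound 4 (0.52 log units; beyond the scatter) and a 9.0-fold higher number from compound 2 to compound 4 (0.95 log units; beyond the scatter). With a 1.1-fold higher number from compound 1 to compound 4 (0.02 log units; within the scatter), (4-fluorobenzyl)(methyl)amino cannot be told apart from (cyclohexylmethyl)amino, so an aromatic ring in this group does not alone bring the lower numbers of compounds 2 and 3. No supporting data on hand explain these steps.

The added methyl, the lost amide hydrogen and the new ring substitution arrive together, so their separate shares cannot be read. Still open, on these data alone, is how the number responds to (4-fluorobenzyl)amino with the amide hydrogen kept, or to an ethyl group in place of the methyl on the nitrogen.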